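A few compounds are considered here, and "the series" means these few. Any claim that something is new, unique, unknown or untested is made for them only; others in the source may bear on it.

Working notes on the amide series. Compound 1 `CCC(=O)N(Cc1ccc(OC)c(O)c1)c1cc(OC)c(OC)c(OC)c1` and compound 2 `COc1ccc(CN(C(=O)C=C(C)C)c2cc(OC)c(OC)c(OC)c2)cc1O` share one core and differ only at the carbonyl carbon. In a functional assay on MGC-803 cells (Homo sapiens) for inhibition, read by MTT assay, with a stated time of 48 h (on this read-out lower numbers stand for stronger inhibition and higher numbers for weaker inhibition), compound 1 gives 50 nM, and in this assay compound 2 gives 320 nM. Among the compounds with values here, of the two numbers so far, compound 2 stands highest, with compound 1 as the only neighbour; the step between them is a 6.4-fold higher number from compound 1 to compound 2 (0.81 log units; beyond the scatter).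

Compound 3 `C/C=C/C(=O)N(Cc1ccc(OC)c(O)c1)c1cc(OC)c(OC)c(OC)c1` is not yet measured. The change from compound 2 is prop-1-en-1-yl in place of 2-methylprop-1-en-1-yl on a carbonyl carbon. Within the data shown here, the one measured step that bears on this position is the step from compound 1 to compound 2, where replacing ethyl by 2-methylprop-1-en-1-yl raised the number beyond the scatter. Compound 3 removes one of the carbons added in that step while keeping the double bond, so it sits between compound 1 and compound 2 in chain size. A move back toward the number of compound 1 is expected, though only part of the way, because a 6.4-fold higher number from compound 1 to compound 2 (0.81 log units; beyond the scatter) came from a change of both size and saturation at once, and compound 3 reverses only part of it.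

In this assay compound 3 is therefore estimated at 150 nM, in the range 60 nM to 400 nM, an expected step of a 2.1-fold lower number from compound 2 to compound 3 (0.33 log units; beyond the scatter).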

Compound 3, half-maximal inhibitory concentration: 27 nM
The estimate for compound 3 lay 5.6-fold (0.74 log units) above the measured number; measured number below the stated range.
By their numbers in this assay, from the lowest: compounds 3 and 1 (each within the scatter of the next); then compound 2.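

In this assay the change at the carbonyl carbon from 2-methylprop-1-en-1-yl to prop-1-en-1-yl gives a 12-fold lower number from compound 2 to compound 3 (1.07 log units; beyond the scatter), so this position responds strongly to a small change in a chain that keeps its double bond. The other comparison gives a 1.9-fold lower number from compound 1 to compound 3 (0.27 log units; within the scatter), which leaves ethyl and prop-1-en-1-yl indistinguishable on this read-out; the double bond alone therefore does not go with a higher number, and among the three compounds shown only compound 2, with its 2-methylprop-1-en-1-yl group, stands apart. Nothing available explains why this group behaves differently from the other two.

The compounds shown leave open how far the chain on the carbonyl carbon can grow or change shape, for instance whether a longer chain such as n-butyl, a cyclopropyl ring or a terminal amine stays with compounds 1 and 3 or moves toward compound 2. They also leave open whether the step seen with 2-methylprop-1-en-1-yl holds on other cores or in other cell lines.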